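This account rests on a few compounds, and the source may have more. Where it says the series, first, only, none or still open, it means among the compounds named here.

Three compounds share one core and differ at a single aromatic carbon. Compound 1 `CN1CCCN(CCn2ccc3ccc(F)cc32)CC1` gives 60% in an assay on HEK293 cells for binding affinity to 5-hydroxytryptamine receptor 7 (Homo sapiens), read by radioligand binding, tested at 1 uM; on this read-out higher numbers stand for more inhibition at the one concentration tested (going by the name of the read-out) and lower numbers for less inhibition. Compound 2 `C=Cc1ccc2ccn(CCN3CCCN(C)CC3)c2c1` gives 79% in this assay, and compound 3 `Cc1ccc2ccn(CCN3CCCN(C)CC3)c2c1` gives 62% in this assay. On these three numbers compound 3 stands second highest; against compound 1 the step is a number 2 percentage points higher from compound 1 to compound 3 (within the scatter), and against compound 2 it is a number 17 percentage points lower from compound 2 to compound 3 (beyond the scatter). Compound 4 `CN1CCCN(CCn2ccc3ccc(-c4cccnc4)cc32)CC1` is not yet measured; it differs from compound 3 in one place: pyridin-3-yl in place of methyl on an aromatic carbon. Among the measured compounds shown here, the steps that bear on this change are the three at the same aromatic carbon: a number 19 percentage points higher from compound 1 to compound 2 (beyond the scatter), a number 2 percentage points higher from compound 1 to compound 3 (within the scatter) and a number 17 percentage points lower from compound 2 to compound 3 (beyond the scatter). For the measured compounds named here, only the steps involving compound 2 moved beyond the scatter, and the vinyl group gave the highest number. Going by the values given here, a six-membered aromatic ring at that carbon has no direct precedent, so the expectation is a modest rise with a broad range: the expected step is a number 8 percentage points higher from compound 3 to compound 4 (within the scatter). For compound 4 the estimate in this assay is 70%, with a range from 45% to 90%.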

Compound 4, a percentage reported as inhibition, at one concentration (the size of the read-out at that concentration, not a potency): 35%
Beside the measured number, compound 4's estimate is 35 percentage points above it, outside the stated range (below it).
By their numbers in this assay, from the lowest: compound 4; then compounds 1 and 3 (each within the scatter of the next); then compound 2.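

In this assay, pyridin-3-yl is the first group at this aromatic carbon to stand beyond the scatter below every other group shown (a number 27 percentage points lower from compound 3 to compound 4 (beyond the scatter); a number 25 percentage points lower from compound 1 to compound 4 (beyond the scatter); a number 44 percentage points lower from compound 2 to compound 4 (beyond the scatter)). Compound 2 stands above compound 3 and compound 4 stands below it, so a group larger than methyl at this carbon does not move the number in one direction across these compounds. Nothing available explains the drop seen with pyridin-3-yl.

On these data alone, it remains open whether the lower number goes with the ring nitrogen or with the aromatic ring as such, and phenyl at this carbon would separate the two. Ethyl at the same carbon would show whether the number seen with vinyl depends on its double bond.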